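Ethoxycarbonyl in place of methyl: compound 2 to compound 4

A few compounds are considered here, and "the series" means these few. Any claim that something is new, unique, unknown or untested is made for them only; others in the source may bear on it.

Going by the values given here, in a functional assay on HL-60 cells (Homo sapiens) for cytotoxicity, read by MTT assay (on this read-out higher numbers stand for weaker inhibition and lower numbers for stronger inhibition), compound 2 (`Cc1ccc(S(=O)(=O)NC(C)C2=CC(=O)c3c(O)ccc(O)c3C2=O)cc1`) gives 30 nM and holds the lower of the two numbers so far. Compound 3 (`CC(NS(=O)(=O)c1ccccc1Br)C1=CC(=O)c2c(O)ccc(O)c2C1=O`) gives 120 nM there. Compound 1 (`Cc1ccc(S(=O)(=O)NC(C2=CC(=O)c3c(O)ccc(O)c3C2=O)C(C)C)cc1`) carries the entry "not determined" (no result reported) and adds nothing to the comparison.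

Compound 4 (`CCOC(=O)c1ccc(S(=O)(=O)NC(C)C2=CC(=O)c3c(O)ccc(O)c3C2=O)cc1`) departs from compound 2 at one place, on an aromatic carbon para to a large group, where ethoxycarbonyl stands in place of methyl (ethoxycarbonyl in place of methyl on an aromatic carbon).

Among the compounds with values here, only one measured step bears on this change: the exchange of the group on the sulfonyl sulfur, a 4.0-fold higher number from compound 2 to compound 3 (0.60 log units; beyond the scatter) and so modest but beyond the scatter. Within the data shown here, it is a single case, it involves a different replacement, and no measured compound carries ethoxycarbonyl. Among the measured compounds shown here, with a 4.0-fold higher number from compound 2 to compound 3 (0.60 log units; beyond the scatter) as the only guide, a modest step to a higher number is expected in this assay rather than a lower one, though a result within the scatter would also fit the data.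

The estimated move is a 2.3-fold higher number from compound 2 to compound 4 (0.37 log units; beyond the scatter) and stays an expectation until measured. The estimate for compound 4 is 70 nM with an expected range of 20 nM to 250 nM on present evidence.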

Compound 4, half-maximal inhibitory concentration: 120 nM
For compound 4 the middle estimate is 1.7-fold (0.23 log units) below the measured one, within the range that was stated.
By their numbers in this assay, from the lowest: compound 2; then compounds 3 and 4 (each within the scatter of the next).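

In this assay, going by these compounds alone, the step of a 4.0-fold higher number from compound 2 to compound 4 (0.60 log units; beyond the scatter) is the first reading at this aromatic carbon para to a large group: methyl can give way to ethoxycarbonyl, which brings in more heavy atoms and two hydrogen-bond acceptors, at a modest cost, and compound 4 still reads 120 nM in the cell assay. Together with a 4.0-fold higher number from compound 2 to compound 3 (0.60 log units; beyond the scatter), which exchanges the whole group on the sulfonyl sulfur, this gives two different changes away from compound 2, and both lead to a higher number, with no compound among those shown going against that direction. No evidence is available on what lies behind the rise at this position.

Open, from the compounds shown here alone, is whether a carboxylic acid, a primary amide or a single fluorine atom on the same aromatic carbon would bring the number back towards that of compound 2 or take it further up. Also open, going by these compounds, is whether a longer ester such as butoxycarbonyl would read like ethoxycarbonyl, which would show how much of this step belongs to the ester group and how much to the chain it carries.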